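The compounds below may be only part of what the source reports. "The series", "measured", "known", "first", "only" and "open" are said of these compounds alone.

Compound 1 `CC(=O)c1ccc(NC(=O)CN(C(=O)c2ccccc2)S(=O)(=O)c2ccc(C)cc2)cc1` is the starting point of this account. In a functional assay, read by spectrophotometry, with a stated time of 20 min (on this read-out lower numbers stand for stronger inhibition and higher numbers for weaker inhibition), compound 1 gives 102000000 nM, the highest of the two numbers that have been measured so far, so among these compounds it is the weakest inhibitor by a margin beyond the scatter. For the measured compounds named here, its one measured neighbour is compound 2 `CC(=O)c1ccc(NC(=O)C(CC(C)C)N(C(=O)c2ccccc2)S(=O)(=O)c2ccc(C)cc2)cc1`, which in this assay gives 11000000 nM; the step of a 9.3-fold lower number from compound 1 to compound 2 (0.97 log units; beyond the scatter) is the only measured change that bears on the present question.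

Compound 3 `CCC(C)C(C(=O)Nc1ccc(C(C)=O)cc1)N(C(=O)c1ccccc1)S(=O)(=O)c1ccc(C)cc1` is not yet measured. It differs from compound 1 by sec-butyl in place of hydrogen on a saturated chain carbon bound to an amide-type nitrogen and a carbonyl carbon. Going by the values given here, the sec-butyl that enters is, like the isobutyl of compound 2, a branched four-carbon chain at the same place, so the step of a 9.3-fold lower number from compound 1 to compound 2 (0.97 log units; beyond the scatter) is the closest guide available, with no second measured step to show how far branching pattern matters.

On that basis compound 3 is expected to follow a similar direction: an estimated step of a 6.8-fold lower number from compound 1 to compound 3 (0.83 log units; beyond the scatter) in this assay, lower than compound 1 and beyond the scatter. The estimate for compound 3 in this assay is 15000000 nM, with a range from 4000000 nM to 60000000 nM.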

Compound 3, half-maximal inhibitory concentration: 10000000 nM
Beside the measured number, compound 3's estimate is 1.5-fold (0.18 log units) above it; measured number inside the range.
By their numbers in this assay, from the lowest: compounds 3 and 2 (each within the scatter of the next); then compound 1.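

In this assay, compound 3 gives a second measured replacement of hydrogen on the saturated chain carbon bound to an amide-type nitrogen and a carbonyl carbon, with a 10-fold lower number from compound 1 to compound 3 (1.01 log units; beyond the scatter), and it runs the same way as the earlier step, so the lower number is no longer tied to isobutyl alone. The exchange of one branched chain for the other, sec-butyl in place of isobutyl, gives a 1.1-fold lower number from compound 2 to compound 3 (0.04 log units; within the scatter), which shows what the earlier pair could not: in this assay these two chains cannot be told apart at this place. Nothing on hand offers an explanation for either step.

It remains open how the number depends on chain size at this carbon, since only hydrogen and the two four-carbon chains are shown, and a methyl group or a longer chain such as n-hexyl could lie anywhere relative to them. Also open, from the compounds shown here alone, is what a benzyl group, or a chain ending in an amine or a carboxylic acid, would do at the same place on the core of compound 1.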